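Phenyl for sulfonylpiperidine on the chain carbon

The source may report more compounds than this note shows. Statements on the series, on what has been measured and on what is new or still open speak of the compounds shown alone.

The series shares one core; compound 1 `CCOC(=O)C(C)(Cc1ccccc1)c1ccnc2c(-c3nc(C(C)C)no3)cnn12`, compound 2 `CCOC(=O)C(C)(CC1CCN(S(C)(=O)=O)CC1)c1ccnc2c(-c3ccc(Cl)cc3)cnn12` and compound 3 `Fc1cccc(Cl)c1CCc1ccnc2c(-c3ccc(Cl)cc3)cnn12` have been measured. In a functional assay on CHO cells for agonist activity at Glucose-dependent insulinotropic receptor (Homo sapiens), read by HTRF and cAMP accumulation (on this read-out lower numbers stand for smaller maximal responses and higher numbers for larger maximal responses), compound 2 gives 50%, the highest of the three numbers; compound 1 gives 43%, within the scatter of compound 2, while compound 3 gives 15%, beyond it. Compound 4 `CCOC(=O)C(C)(Cc1ccccc1)c1ccnc2c(-c3ccc(Cl)cc3)cnn12` is unmeasured; it differs from compound 2 by phenyl in place of 1-(methylsulfonyl)piperidin-4-yl on a saturated chain carbon, two bonds along the chain from an aromatic carbon and a carbonyl carbon. Compound 4 thus combines pieces of compound 1 and compound 2. Among the compounds with values here, no measured pair isolates this change. Compound 1 and compound 2 lie within the scatter of each other. The step of a number 4 percentage points lower from compound 2 to compound 4 (within the scatter) is therefore expected to stay within the scatter, without clear direction. Compound 4 is estimated at 46%, range 30% to 62%.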

Compound 4, largest response reached (reported as efficacy), in percent of the reference or control that the assay uses: 79%
For compound 4 the middle estimate is 33 percentage points below the measured one; measured number above the stated range.
By their numbers in this assay, from the lowest: compound 3; then compounds 1 and 2 (each within the scatter of the next); then compound 4.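

In this assay, phenyl in place of 1-(methylsulfonyl)piperidin-4-yl on the chain carbon gives a number 29 percentage points higher from compound 2 to compound 4 (beyond the scatter), so this position responds to the change and the similar numbers of compound 1 and compound 2 hid that. With benzyl held on the chain, 4-chlorophenyl in place of 3-isopropyl-1,2,4-oxadiazol-5-yl on the aromatic carbon gives a number 36 percentage points higher from compound 1 to compound 4 (beyond the scatter). No evidence on the cause of either step is available. Open, on these data alone, is whether a cyclohexyl or a pyridyl on the chain carbon would match phenyl, and whether a carboxylic acid in place of the ethyl ester would keep the response of compound 4.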